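A Longer Chain to the Outer Aromatic Ring

The source may report more compounds than this note shows. Statements on the series, on what has been measured and on what is new or still open speak of the compounds shown alone.

Compound 1 `Cc1ccc(COC(=O)N(c2ccccc2)C2CN3CCC2CC3)cc1F` stands as the stronger of the two compounds measured in an assay on CHO cells for displacement of a labelled ligand from muscarinic acetylcholine receptor M5 (Homo sapiens), read by scintillation counting, with a stated time of 2 h; a lower number here means a stronger inhibitor, a higher number a weaker inhibitor: compound 1 gives 30 nM, whereas compound 2 `COc1ccc(CCCOC(=O)N(c2ccccc2)C2CN3CCC2CC3)cc1F` gives 260 nM, a gap beyond the usual scatter. Compound 3 `O=C(OCCCc1ccccc1)N(c1ccccc1)C1CN2CCC1CC2` is not yet measured. Relative to compound 1 it carries phenethyl in place of 3-fluoro-4-methylphenyl on a saturated chain carbon bound to an oxygen next to a carbonyl group. Compound 2 likewise sets its ring at the end of a longer chain, and its 260 nM suggests a weaker number for such a change. A step to a higher number, beyond the scatter, is expected. Compound 3 is estimated at 200 nM, between 60 nM and 700 nM. This expectation corresponds to a 6.7-fold higher number from compound 1 to compound 3 (0.82 log units; beyond the scatter).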

Compound 3, inhibition constant: 260 nM
Estimate against measurement, compound 3: 1.3-fold (0.11 log units) below; low and high end bracket the measured number.
By their numbers in this assay, from the lowest: compound 1; then compounds 2 and 3 (each within the scatter of the next).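

In this assay, going from the 3-fluoro-4-methylbenzyl group to the 3-phenylpropyl group gives a clearly weaker binder (an 8.7-fold higher number from compound 1 to compound 3 (0.94 log units; beyond the scatter)). On the longer chain, the bare phenyl of compound 3 and the 3-fluoro-4-methoxyphenyl of compound 2 cannot be told apart (no change at the digits printed from compound 2 to compound 3 (within the scatter)), so at this chain length those ring substituents show no effect. Nothing available explains either result. Still open, as far as these compounds go, is whether a plain benzyl group, with neither fluorine nor methyl, would match compound 1, which would show whether chain length alone accounts for the step. From the compounds shown here alone, how a still longer chain would read also remains open.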